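Compound 1 Faces a Furan for Its Methylphenyl

The compounds below may be only part of what the source reports. "The series", "measured", "known", "first", "only" and "open" are said of these compounds alone.

Compound 1 `Cc1ccc(C2C(C#N)=C(N)N(c3ccc(S(N)(=O)=O)cc3)C3=C2CCCC3)cc1` is one of three analogues measured in a functional assay on Ehrlich cells (Mus musculus) for cytotoxicity, read by trypan blue exclusion, with a stated time of 2 h, tested at 25 ug/mL (a higher number here means a stronger effect of the compound at the concentration tested, a lower number a weaker effect), and in that test compound 1 gives 30%. Among the three numbers it stands second highest. Its nearest neighbour is compound 3 `N#CC1=C(N)N(c2ccc(S(N)(=O)=O)cc2)C2=C(CCCC2)C1c1c(O)ccc2ccccc12`, which in this assay gives 5%; the furthest is compound 2 `COc1ccc(C2C(C#N)=C(N)N(c3ccc(S(N)(=O)=O)cc3)C3=C2CCCC3)cc1`, which in this assay gives 90%. Both steps away from compound 1 lie beyond the scatter: a number 60 percentage points higher from compound 1 to compound 2 (beyond the scatter), and a number 25 percentage points lower from compound 1 to compound 3 (beyond the scatter). The two other compounds are also far apart, since a number 85 percentage points lower from compound 2 to compound 3 (beyond the scatter).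

Compound 4 `Cc1ccc(C2C(C#N)=C(N)N(c3ccc(S(N)(=O)=O)cc3)C3=C2CCCC3)o1` is not yet measured. It differs from compound 1 in one place: 5-methylfuran-2-yl in place of 4-methylphenyl on a saturated ring carbon.

The measured steps bear on this change only loosely. Each of them alters the group on the same saturated ring carbon, and each is large, so the group at this position clearly decides much of the read-out in this assay. Yet none of them introduces a five-membered aromatic ring with one hetero atom, so the direction of the new step cannot be read off the earlier ones; one step went strongly up and the other modestly down. Compound 4 is therefore expected to give about 45% in this assay, with a wide range from 10% to 85%. This estimate means an expected step of a number 15 percentage points higher from compound 1 to compound 4 (beyond the scatter), which is small relative to the measured steps and could fall within the scatter.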

Compound 4, a percentage reported as activity, at one concentration (the size of the read-out at that concentration, not a potency): 10%
Beside the measured number, compound 4's estimate is 35 percentage points above it; low and high end bracket the measured number.
By their numbers in this assay, from the lowest: compounds 3 and 4 (each within the scatter of the next); then compound 1; then compound 2.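

In this assay, within the data shown here, putting 5-methylfuran-2-yl in place of 4-methylphenyl on the saturated ring carbon gives a number 20 percentage points lower from compound 1 to compound 4 (beyond the scatter) and so places a five-membered aromatic ring with 1 hetero atom at the low end of this small series, a result the earlier steps could not settle. The same low range is shared by two quite different groups, 5-methylfuran-2-yl and 2-hydroxynaphthalen-1-yl, as the comparison gives a number 5 percentage points higher from compound 3 to compound 4 (within the scatter), so a low read-out at this position is not tied to one kind of ring. The step of a number 80 percentage points lower from compound 2 to compound 4 (beyond the scatter) adds a third comparison in which compound 2 stands clear of the others, leaving its 4-methoxyphenyl group as the only one shown here with a high read-out.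

Nothing available explains why the read-out falls with this change. The compounds shown also leave open whether the methyl on the furan matters, and how a plain furan-2-yl, a 5-methylthiophen-2-yl or a 4-aminophenyl group would read at this position.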